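A few compounds are considered here, and "the series" means these few. Any claim that something is new, unique, unknown or untested is made for them only; others in the source may bear on it.

Measured in a functional assay on MCF7 cells (Homo sapiens) for antiproliferative activity, read by MTT assay, with a stated time of 3 days; a higher number here means a weaker inhibitor, a lower number a stronger inhibitor:
- Compound 1 `Cc1ccc(C#Cc2cn(C/C=C\CN3C(=O)c4ccccc4C3=O)c(=O)[nH]c2=O)cc1`: > 100000 nM, a limit
- Compound 2 `O=C1c2ccccc2C(=O)N1C/C=C\Cn1cc(C#Cc2ccc(Br)cc2)c(=O)[nH]c1=O`: > 100000 nM, a limit
- Compound 3 `CCCCCCC#Cc1cn(C/C=C/CN2C(=O)c3ccccc3C2=O)c(=O)[nH]c1=O`: 24000 nM

For the measured compounds named here, compound 3 holds the only true number here, and the rest of the evidence is the limit of > 100000 nM in this assay, at which 2 of the 3 values shown sit. Compound 4 `CCCCCc1ccc(C#Cc2cn(C/C=C/CN3C(=O)c4ccccc4C3=O)c(=O)[nH]c2=O)cc1` differs from compound 3 by 4-pentylphenyl in place of hexyl on a triple-bonded carbon. Going by the values given here, the one measured step, a step that the two limits leave unreadable from compound 1 to compound 2, gives no size to carry over. Compound 1 also bears an aromatic ring on the triple bond, though its double bond differs from that of compound 3. Compound 1 shows > 100000 nM, a limit. A modest weakening is therefore expected, with an estimated 1.5-fold higher number from compound 3 to compound 4 (0.16 log units; within the scatter). Compound 4 is expected to give 35000 nM, with an estimated range of 10000 nM to 100000 nM.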

Compound 4, half-maximal inhibitory concentration: 5600 nM
Estimate against measurement, compound 4: 6.3-fold (0.80 log units) above, outside the stated range (below it).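

In this assay, the triple-bonded carbon proved open to change, with 4-pentylphenyl in place of hexyl giving a 4.3-fold lower number from compound 3 to compound 4 (0.63 log units; beyond the scatter). For the compounds shown here, this is the first readable step, and it ties an aromatic ring carrying a pentyl chain at this place to a stronger result than the hexyl chain gives. The rest of the evidence remains thin: the limit of > 100000 nM in this assay, at which 2 of the 4 values shown sit.

The ring and the pentyl chain enter together, and the compounds shown do not separate them. From the compounds shown here alone, how a plain phenyl, or an amine on the pentyl chain, would read at this place remains open.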